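The compounds below may be only part of what the source reports. "The series", "measured", "known", "first", "only" and "open" are said of these compounds alone.

Compound 1 `Nc1nc(Cl)nc(Nc2ccc(N3CCOCC3=O)cc2)n1`: 67%
Compound 2 `O=C1COCCN1c1ccc(Nc2nc(Cl)nc(NC3CCCCC3)n2)cc1`: 56%
Compound 3 `O=C1COCCN1c1ccc(Nc2nc(Cl)nc(Nc3ccccc3)n2)cc1`: 76%

All three were tested in a functional assay on the whole organism (strain Swiss) for inhibition, with Mus musculus as the target, with a stated time of 30 min, at a dose of 5 mg/kg by the intraperitoneal route; on this read-out lower numbers stand for a weaker effect and higher numbers for a stronger effect at the one dose given. Compound 3 gives the largest of the three numbers, but its gap to compound 1 lies within the scatter, so those two cannot be told apart; only its gap to compound 2 is real, a number 20 percentage points higher from compound 2 to compound 3 (beyond the scatter). Compound 4 `COc1ccc(Nc2nc(Cl)nc(Nc3ccc(N4CCOCC4=O)cc3)n2)cc1` is the next step, in which (methoxy in place of hydrogen on an aromatic carbon), turning the anilino into (4-methoxyphenyl)amino. Among the measured compounds shown here, none of the measured steps touches this position: a number 11 percentage points lower from compound 1 to compound 2 (beyond the scatter) and a number 9 percentage points higher from compound 1 to compound 3 (within the scatter) both swap the group on a nitrogen on an aromatic ring, and nothing here shows what a methoxy does. For the measured compounds named here, with no guiding step, the expected change in this assay is a number 4 percentage points lower from compound 3 to compound 4 (within the scatter), none beyond the scatter. Compound 4 is therefore estimated at 72%, within 55% to 88%.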

Compound 4, a percentage reported as inhibition, in the whole organism at one dose (the size of the read-out at that dose, not a potency): 47%
Estimate against measurement, compound 4: 25 percentage points above; measured number outside the range, below it.
By their numbers in this assay, from the lowest: compounds 4 and 2 (each within the scatter of the next); then compounds 1 and 3 (each within the scatter of the next).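

In this assay, adding a methoxy to the phenyl ring, para to a large group, is not neutral: it gives a clear fall (a number 29 percentage points lower from compound 3 to compound 4 (beyond the scatter)). The 4-methoxyphenyl group also falls short of the hydrogen it replaces (a number 20 percentage points lower from compound 1 to compound 4 (beyond the scatter)), yet it cannot be told apart from cyclohexyl (a number 9 percentage points lower from compound 2 to compound 4 (within the scatter)). Nothing measured here accounts for the fall.

From the compounds shown here alone, whether this fall is specific to methoxy remains open. A fluorine, a methyl or a hydroxyl at this place would help to show whether any added group has the same effect.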